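A few compounds are considered here, and "the series" means these few. Any claim that something is new, unique, unknown or untested is made for them only; others in the source may bear on it.

Compound 1 `COc1cc(NC(C)CCCNC(=O)Nc2cccc(Cl)c2)c2ncccc2c1` gives 17000 nM in a functional assay on L1210 cells (Mus musculus) for inhibition, read by MTT assay, with a stated time of 72 h; on this read-out lower numbers stand for stronger inhibition and higher numbers for weaker inhibition; compound 2 `COc1cc(NC(C)CCCNC(=O)NNC(=O)Nc2ccc(F)cc2)c2ncccc2c1` gives 104000 nM.

For the measured compounds named here, compound 1 holds the lowest of these two numbers, and its only neighbour is compound 2, reached by a 6.1-fold higher number from compound 1 to compound 2 (0.79 log units; beyond the scatter). Compound 3 `COc1cc(NC(C)CCCNC(=O)NNC(=O)Nc2ccc(Br)cc2)c2ncccc2c1` differs from compound 1 by ((4-bromophenyl)carbamoyl)amino in place of 3-chlorophenyl on an amide-type nitrogen. Going by the values given here, the single measured step that bears on this change is the one to compound 2, in which ((4-fluorophenyl)carbamoyl)amino replaced 3-chlorophenyl on the same amide-type nitrogen, giving a 6.1-fold higher number from compound 1 to compound 2 (0.79 log units; beyond the scatter). Compound 3 carries the same kind of replacement. The step expected for compound 3 is therefore a 5.0-fold higher number from compound 1 to compound 3 (0.70 log units; beyond the scatter), weaker inhibition in line with a 6.1-fold higher number from compound 1 to compound 2 (0.79 log units; beyond the scatter). Compound 3 is estimated at 85000 nM, within 25000 nM to 280000 nM.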

Compound 3, half-maximal inhibitory concentration: 51000 nM
For compound 3 the middle estimate is 1.7-fold (0.22 log units) above the measured one, within the range that was stated.
By their numbers in this assay, from the lowest: compound 1; then compound 3; then compound 2.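

In this assay, a second replacement on this amide-type nitrogen again weakens inhibition, with a 3.0-fold higher number from compound 1 to compound 3 (0.48 log units; beyond the scatter) and so both entering groups shown stand on the weaker side of compound 1. The halogen on the entering group also matters: bromo in place of fluoro on an aromatic carbon gives a 2.0-fold lower number from compound 2 to compound 3 (0.31 log units; beyond the scatter) and recovers part of the loss. No measurement given here explains either step. Going by these compounds, how an amine or a carboxylic acid in place of the bromo would fare remains open, as does a longer chain on the same nitrogen.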